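This account rests on a few compounds, and the source may have more. Where it says the series, first, only, none or still open, it means among the compounds named here.

Among the measured compounds shown here, in a functional assay for inhibition, with Homo sapiens as the target (a lower number here means a stronger inhibitor, a higher number a weaker inhibitor), compound 2 `COC(=O)C(Cc1cccc(OCC(=O)O)c1)c1nc(-c2ccccc2)c(-c2ccccc2)o1` gives 80 nM, the only exact number available so far. Compound 1 `CCOC(=O)/C(=C\c1cccc(OCC(=O)OC(C)(C)C)c1)c1nc(-c2ccccc2)c(-c2ccccc2)o1` is reported only as a limit of the assay, > 60000 nM. The two compounds differ in more than one place, so their values do not isolate the effect of any single change.

The next compound to be tested is compound 3 `CC(C)(C)C(Cc1cccc(OCC(=O)O)c1)c1nc(-c2ccccc2)c(-c2ccccc2)o1`. It carries tert-butyl in place of methoxycarbonyl on a saturated chain carbon bound to an aromatic carbon and a saturated chain carbon. For the measured compounds named here, no measured pair shows this exchange, or any other single change, so the expectation starts from compound 2 at 80 nM and rests on the structural change alone. A moderate weakening is expected, though the data cannot rule out a result within the usual scatter. The expected size of the change is a 3.1-fold higher number from compound 2 to compound 3 (0.49 log units; beyond the scatter). For compound 3 the estimated half-maximal inhibitory concentration is 250 nM, with an expected range of 50 nM to 1500 nM.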

Compound 3, half-maximal inhibitory concentration: 3660 nM
Estimate against measurement, compound 3: 15-fold (1.17 log units) below; measured number outside the range, above it.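

In this assay, among the compounds shown here, the exchange of methoxycarbonyl for tert-butyl on a saturated chain carbon bound to an aromatic carbon and a saturated chain carbon gives the first change that can be read on its own: a 46-fold higher number from compound 2 to compound 3 (1.66 log units; beyond the scatter). The exchange leaves the count of heavy atoms the same and takes out both oxygen atoms and both hydrogen-bond acceptors, so this position responds strongly to a change of group even when that count stays fixed. Compound 3 has an exact value, so this step can be read in full, and among the compounds shown only compound 1 is reported as a limit of the assay: the limit of > 60000 nM in this assay, at which 1 of the 3 values shown sits.

On these data alone, a single exchange cannot separate the loss of the oxygen atoms from the change to a branched all-carbon group, so the feature behind the step remains open. Also open, as far as these compounds go, is whether a primary amide or an isopropyl group on this carbon would stay close to compound 2 at 80 nM or move towards compound 3 at 3660 nM.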